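Fluoro to iodo on the aromatic ring

The compounds below may be only part of what the source reports. "The series", "measured", "known", "first", "only" and "open" are said of these compounds alone.

In a functional assay on T98G cells (Homo sapiens) for cytotoxicity, read by MTT assay, with a stated time of 48 h (a higher number here means a weaker inhibitor, a lower number a stronger inhibitor), compound 1 (`CC(=NNC(=S)Nc1cccc([N+](=O)[O-])c1)c1ccccn1`) gives 140 nM while compound 2 (`C/C(=N\NC(=S)Nc1cccc(F)c1)c1ccccn1`) gives 12 nM and compound 3 (`CC(=NNC(=S)Nc1cccc(F)c1)c1ccccn1`) gives 12 nM as well. Compound 3 therefore stands level with compound 2, and the two together hold the lowest of the three numbers.

Compound 4 (`CC(=NNC(=S)Nc1cccc(I)c1)c1ccccn1`) differs from compound 3 by a single exchange (iodo in place of fluoro on an aromatic carbon): iodo in place of fluoro on an aromatic carbon, meta to a large group.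

For the measured compounds named here, two measured steps bear on this exchange. The step of no change at the digits printed from compound 2 to compound 3 (within the scatter) goes only with the fact that one of compounds 2 and 3 is drawn with a defined configuration and the other without, at the place where they differ and leaves the substituent untouched, so it gives no guide to size. Going by the values given here, the step of a 12-fold lower number from compound 1 to compound 3 (1.07 log units; beyond the scatter) is the one measured exchange at this place on the aromatic ring and shows how far the number can move there. Among the compounds with values here, no iodo compound has been measured, so the direction remains uncertain. Compound 3 at 12 nM already shares the lowest number, so a small rise is expected rather than a further fall.

The expected move is a 2.1-fold higher number from compound 3 to compound 4 (0.32 log units; beyond the scatter) in this assay with no change still possible. For compound 4 the estimated value is 25 nM with an expected range from 6 nM to 100 nM in this series.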

Compound 4, half-maximal inhibitory concentration: 61 nM
Estimate against measurement, compound 4: 2.4-fold (0.39 log units) below; the range from low to high includes it.
By their numbers in this assay, from the lowest: compounds 2 and 3 (each within the scatter of the next); then compound 4; then compound 1.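

In this assay this aromatic carbon does not treat the two halogens alike: the exchange of fluoro for iodo gives a 5.1-fold higher number from compound 3 to compound 4 (0.71 log units; beyond the scatter) and is beyond the scatter, so the number here moves with a change between single-atom substituents as well as with the loss of nitro. The nitro comparison also changes in size, since a 2.3-fold lower number from compound 1 to compound 4 (0.36 log units; beyond the scatter) is a smaller move than a 12-fold lower number from compound 1 to compound 3 (1.07 log units; beyond the scatter) and places compound 4 apart from both compound 1 and compound 3 in the order of numbers. For the compounds shown here, the only information available concerns how compounds 2 and 3 are drawn and offers no explanation for the move from fluoro to iodo.

The compounds shown leave open whether chloro or bromo on this aromatic carbon would give a number between those of compound 3 and compound 4, and how an amine or a carboxylic acid would behave there. They also leave open how the number responds when fluoro is kept and a longer chain replaces the methyl on the shared core.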